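A few compounds are considered here, and "the series" means these few. Any claim that something is new, unique, unknown or untested is made for them only; others in the source may bear on it.

Compound 3 `CC#C[C@H]1CN(S(=O)(=O)c2ccc(N)nc2)CCN1c1ccc(C(C)=O)cc1` stands at the edge of what this series shows. In an assay on cells (Hepatocyte) for inhibition of glucokinase regulatory protein (Mus musculus), with stated times of 20 min and 40 min (a lower number here means that less compound is needed, a higher number that more compound is needed for the effect), compound 3 gives > 12500 nM, which is a limit of the assay and not a number. Compound 1 `CC#C[C@H]1CN(S(=O)(=O)c2ccc(N)nc2)CCN1c1ccc(S(=O)(=NC)C(F)(F)F)cc1` in this assay gives 2060 nM. Compound 2 `CC#C[C@H]1CN(S(=O)(=O)c2ccc(N)nc2)CCN1c1ccc(S(=O)(=O)Nc2ccccc2)cc1` in this assay gives > 12500 nM, again a limit. The two steps out of compound 1 are an at least 6.0-fold higher number from compound 1 to compound 2 (0.78 log units; beyond the scatter) and an at least 6.0-fold higher number from compound 1 to compound 3 (0.78 log units; beyond the scatter); the step that the two limits leave unreadable from compound 2 to compound 3, since both sit at the limit of > 12500 nM in this assay, at which 2 of the 3 values shown sit. Compound 4 `CC#C[C@H]1CN(S(=O)(=O)c2ccc(N)nc2)CCN1c1ccc([S+](C)[O-])cc1` carries a group of 3 heavy atoms (1 carbon, 1 oxygen, 1 sulfur; no ring) in place of a group of 3 heavy atoms (2 carbon, 1 oxygen; no ring), on an aromatic carbon. The group entering resembles the group that leaves on the step from compound 1 to compound 3 more than acetyl does, so the step of an at least 2.0-fold lower number from compound 3 to compound 4 (0.31 log units; beyond the scatter) is expected to run toward lower numbers, though with wide uncertainty. Compound 4 is therefore estimated at 6000 nM, within 1500 nM to 20000 nM.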

Compound 4, half-maximal effective concentration: > 12500 nM
Compound 4 gave a limit, no number; the forecaster's own chance of this, stated with the estimate: 35%; at least 2.0-fold (0.31 log units) between middle value and limit.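

In this assay, compound 4 also sits at a limit of the assay, so a third group on the aromatic carbon para to a large group gives no number: the limit of > 12500 nM in this assay, at which 3 of the 4 values shown sit.

The steps among compound 2, compound 3 and compound 4 cannot be read. Within the data shown here, the one readable step is an at least 6.0-fold higher number from compound 1 to compound 4 (0.78 log units; beyond the scatter), so the smaller sulfur group does not retain the measurable result seen with the larger one.

From the compounds shown here alone, how far apart the three limited compounds lie stays open. Also open, going by these compounds, is whether a nitrile or an amine at this place would give a number.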